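The source may hold more compounds than are shown below. What is called first, only, known or untested is meant among the compounds shown, and "the series" means these compounds.

Measured compounds:
Compound 1 `CC(C)(C)c1ccc(OC(=O)c2cn(-c3ccccc3)nc2-c2cccnc2)cc1`. In a functional assay on HeLa cells (Homo sapiens) for cytotoxicity, read by MTT assay, with a stated time of 48 h (a higher number here means a weaker inhibitor, a lower number a stronger inhibitor), compound 1 gives > 100000 nM, a limit of the assay.
Compound 2 `CCc1ccc(OC(=O)c2cn(-c3ccccc3)nc2-c2ccncc2)cc1`. In this assay compound 2 gives > 100000 nM, also a limit.
Compound 3 `CC(C)c1cccc(OC(=O)c2cn(-c3ccccc3)nc2-c2ccncc2)c1`. In this assay compound 3 gives > 100000 nM, again a limit.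

Compound 3 thus stands at a limit, as do the two other values shown, all sitting at the limit of > 100000 nM in this assay, at which 3 of the 3 values shown sit. For the measured compounds named here, the one step between measured compounds, a step that the two limits leave unreadable from compound 2 to compound 3, is unreadable for that reason.

Compound 4 `CC(C)(C)c1ccc(OC(=O)c2cn(-c3ccccc3)nc2-c2ccncc2)cc1` differs from compound 3 by 4-(tert-butyl)phenyl in place of 3-isopropylphenyl on an oxygen next to a carbonyl group. Going by the values given here, no measured step bears readably on this change; compound 1 already carries 4-(tert-butyl)phenyl and sits at the same limit. Accordingly no step beyond the scatter is expected, a step that the limit leaves unreadable from compound 3 to compound 4, and compound 4 is expected to give 150000 nM, within 50000 nM to 1000000 nM, most likely reported as a limit again.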

Compound 4, half-maximal inhibitory concentration: 35400 nM
Compound 4: middle estimate off by 4.2-fold (0.63 log units), on the high side; measured number below the stated range.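

In this assay, 4-(tert-butyl)phenyl in place of 3-isopropylphenyl on an oxygen next to a carbonyl group gives an at least 2.8-fold lower number from compound 3 to compound 4 (0.45 log units; beyond the scatter). With the pyridin-4-yl kept, tert-butyl in place of ethyl on an aromatic carbon gives an at least 2.8-fold lower number from compound 2 to compound 4 (0.45 log units; beyond the scatter). The tert-butyl alone does not suffice, since pyridin-4-yl in place of pyridin-3-yl on an aromatic carbon gives an at least 2.8-fold lower number from compound 1 to compound 4 (0.45 log units; beyond the scatter).

Going by these compounds, the full size of these steps remains open, and the step between compound 2 and compound 3 cannot be read: the limit of > 100000 nM in this assay, at which 3 of the 4 values shown sit. Also open is how an amine or a carboxylic acid in place of tert-butyl on that aromatic carbon would compare with compound 4.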